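Compound 3 to compound 4: swapping the aryl amide

This account rests on a few compounds, and the source may have more. Where it says the series, first, only, none or still open, it means among the compounds named here.

Measured in a functional assay on Caco-2 cells (Homo sapiens) for antiproliferative activity, read by MTT assay, with a stated time of 48 h; on this read-out higher numbers stand for weaker inhibition and lower numbers for stronger inhibition:
compound 1 `CCn1c(C(=O)NCCCN(C)C)ccc1C(CC)(CC)c1ccc(OCCC(O)(CC)CC)c(C)c1` gives 490 nM
compound 2 `CCn1c(C(=O)N(CCC#N)CCC#N)ccc1C(CC)(CC)c1ccc(OCCC(O)(CC)CC)c(C)c1` gives > 50000 nM (a limit)
compound 3 `CCn1c(C(=O)Nc2cccc(C(F)(F)F)c2)ccc1C(CC)(CC)c1ccc(OCCC(O)(CC)CC)c(C)c1` gives > 50000 nM (a limit)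

Compound 3 sits at the limit of > 50000 nM in this assay, at which 2 of the 3 values shown sit, so it has a limit and no number. Compound 4 `CCOc1ccc(NC(=O)c2ccc(C(CC)(CC)c3ccc(OCCC(O)(CC)CC)c(C)c3)n2CC)cc1` carries 4-ethoxyphenyl in place of 3-(trifluoromethyl)phenyl on an amide-type nitrogen. The nearest evidence is an at least 100-fold higher number from compound 1 to compound 3 (2.00 log units; beyond the scatter), with 3-(trifluoromethyl)phenyl in place of 3-(dimethylamino)propyl. The other step, a step that the two limits leave unreadable from compound 2 to compound 3, gives no size. Compound 4 keeps a phenyl group on that nitrogen, as compound 3 does, so the large step in an at least 100-fold higher number from compound 1 to compound 3 (2.00 log units; beyond the scatter) is expected to persist and no step beyond the scatter is expected in this assay. The expected step is an at least 1.4-fold lower number from compound 3 to compound 4 (0.15 log units; that floor lies within the scatter). Compound 4 is estimated at 35000 nM, within 8000 nM to 70000 nM, and may well return only a limit.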

Compound 4, half-maximal inhibitory concentration: > 50000 nM
Compound 4 ended at the assay's limit; the forecaster's own chance of this, stated with the estimate: 60%; middle value at least 1.4-fold (0.15 log units) away from the limit.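

In this assay compound 4 gives > 50000 nM, a limit and not a number. Against the 3-(dimethylamino)propyl amide the change reads as an at least 100-fold higher number from compound 1 to compound 4 (2.00 log units; beyond the scatter), so a second substituted phenyl on the amide-type nitrogen, with 4-ethoxyphenyl in place of 3-(trifluoromethyl)phenyl, also ends at the limit: the limit of > 50000 nM in this assay, at which 3 of the 4 values shown sit. The steps from compound 2 and from compound 3 to compound 4 cannot be read, as both ends of each are limits.

As far as these compounds go, whether the activity of compound 1 rests on the terminal dimethylamino group or on the propyl chain stays open. A plain butyl amide, or a phenyl ring carrying a dimethylamino group, would separate the two.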